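This account rests on a few compounds, and the source may have more. Where it says the series, first, only, none or still open, it means among the compounds named here.

Measured so far in an ADME assay on microsomes from liver (Homo sapiens) for metabolic stability, read by LC-MS, with a stated time of 10 min (on this read-out lower numbers stand for a less stable compound and higher numbers for a more stable compound), are three compounds:
compound 1 `C[C@@H]1CN(c2cccc3c2C[C@H](CN(C)[C@H]2CCCc4cccnc42)NC3)C[C@H](C)N1` with 100%
compound 2 `CN(C[C@H]1Cc2c(cccc2N2CCNC(C)(C)C2)CN1)[C@H]1CCCc2cccnc21` with 100%
compound 3 `CN(C[C@H]1Cc2c(cccc2N2CCN3CCC[C@H]3C2)CN1)[C@H]1CCCc2cccnc21` with 36.6%

In this assay compound 3 stands lowest of the three, well apart from both others. Set against it, compound 4 `CN(C[C@H]1Cc2c(cccc2N2CCN3CCC[C@@H]3C2)CN1)[C@H]1CCCc2cccnc21` shows this difference: the two compounds have the same atoms and bonds and differ only in configuration as drawn: 1 of 3 stereo elements differ; a stereocentre at a saturated ring carbon is drawn S in compound 3 and R in compound 4 and so it keeps the same group on the aromatic carbon.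

Going by the values given here, no measured step is a change of configuration alone, so the evidence is indirect. Replacing the group on the aromatic carbon gave a number 63.4 percentage points lower from compound 1 to compound 3 (beyond the scatter) and likewise a number 63.4 percentage points lower from compound 2 to compound 3 (beyond the scatter) as two large steps, while exchanging one dimethylpiperazinyl group for the other gave no change at the digits printed from compound 1 to compound 2 (within the scatter) as the remaining step. Compound 4 carries the group of compound 3, so a step of that large size is not expected, and no direction is favoured. Among the compounds with values here, the data hold no pair of stereoisomers, so the range stays wide. The estimated step is a number 3.4 percentage points higher from compound 3 to compound 4 (within the scatter) in this case. Compound 4 is expected at 40% with an estimated range from 15% to 75% in all.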

Compound 4, percent of the compound remaining: 52.2%
Estimate against measurement, compound 4: 12.2 percentage points below; the range from low to high includes it.
By their numbers in this assay, from the lowest: compound 3; then compound 4; then compounds 1 and 2 (each within the scatter of the next).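

In this assay, going by these compounds alone, the earlier compounds held no pair of stereoisomers, but here the stereocentre at a saturated ring carbon, drawn S in compound 3 and R in compound 4, comes with a number 15.6 percentage points higher from compound 3 to compound 4 (beyond the scatter). This step can be assigned to that stereocentre alone because nothing else separates the two compounds: the fact that compounds 3 and 4 differ only in the configuration as drawn

Even so, the R form stays far from the dimethylpiperazinyl compounds, with a number 47.8 percentage points lower from compound 2 to compound 4 (beyond the scatter) and a number 47.8 percentage points lower from compound 1 to compound 4 (beyond the scatter), so the choice of group on the aromatic carbon outweighs the configuration in this set.

On these data alone, it remains open whether an unsubstituted piperazin-1-yl or a morpholin-4-yl group on the aromatic carbon would fall with compound 1 and compound 2 or with compound 3 and compound 4. The compounds shown also leave open whether a six-membered ring in place of the five-membered one would keep the same difference between its S and R forms.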